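The source may hold more compounds than are shown below. What is called first, only, known or untested is meant among the compounds shown, and "the series" means these compounds.

Measured compounds in a toxicity assay on A549 cells (Homo sapiens) for cytotoxicity, read by luminescence and CellTiter-Glo, with a stated time of 48 h; a higher number here means that more compound is tolerated, a lower number that less compound is tolerated:
Compound 1 `CCCCOc1ccc(-c2nc3ncccn3c2NC(C)(C)CC(C)(C)C)cc1` gives 29000 nM in this assay.
Compound 2 `CCCCOc1ccc(-c2nc3ncccn3c2NCC2CC2)cc1` reaches only the limit of this assay, at > 100000 nM.
Compound 3 `CCOC(=O)CCCOc1ccc(-c2nc3ncccn3c2NC2CCCCC2)cc1` likewise reaches only the limit of this assay, at > 100000 nM.

Compound 3 therefore stands without a number of its own: its value is a limit, and the limit of > 100000 nM in this assay, at which 2 of the 3 values shown sit, shows that it is not alone there. Among the measured compounds shown here, the one measured step, an at least 3.4-fold higher number from compound 1 to compound 2 (0.53 log units; beyond the scatter), concerns the substituent on the ring nitrogen and not the aryl ether chain, so it gives no direct guidance on the change now in question.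

The step from compound 3 to compound 4 `COc1ccc(-c2nc3ncccn3c2NC2CCCCC2)cc1` is hydrogen in place of 2-(ethoxycarbonyl)ethyl on a saturated chain carbon bound to an oxygen on an aromatic ring. For the measured compounds named here, no measured step alters this chain, and the only comparison that exists within the set moves in the direction of a higher number or a limit. With compound 3 already at the limit of this assay, there is no ground to expect a drop beyond the scatter, though a number below the limit cannot be ruled out. Compound 4 is therefore estimated at about 90000 nM, within a range from 30000 nM to 100000 nM. The expected step is an at least 1.1-fold lower number from compound 3 to compound 4 (0.04 log units; that floor lies within the scatter), that is, essentially no change in this assay.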

Compound 4, half-maximal cytotoxic concentration: > 100000 nM
Compound 4: a limit, no number; the forecaster's own chance of this, stated with the estimate: 60%; middle value at least 1.1-fold (0.04 log units) away from the limit.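

Compound 4 gives only a limit in this assay, at > 100000 nM. Compound 3 also stands at a limit, so no step can be read between compound 3 and compound 4. The compounds shown leave open whether 3-(ethoxycarbonyl)propoxy and methoxy differ at all in this read-out, and this limit is a shared one: the limit of > 100000 nM in this assay, at which 3 of the 4 values shown sit.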